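A New Group on the Ring Nitrogen of Compound 1

The source may report more compounds than this note shows. Statements on the series, on what has been measured and on what is new or still open speak of the compounds shown alone.

Measured so far:
Compound 1 `CCOC(=O)C1=Cc2ccccc2OC1(OCc1cn(-c2ccc(F)cc2)nn1)C(F)(F)F`: 9100 nM
Compound 2 `CCOC(=O)C1=Cc2ccccc2OC1(OCc1cc(-c2ccc(Br)cc2)no1)C(F)(F)F`: > 150000 nM
Compound 3 `CCOC(=O)C1=Cc2ccccc2OC1(OCc1cc(-c2ccc(Cl)cc2)no1)C(F)(F)F`: 18200 nM

These three compounds share one core and were tested in a functional assay on MCF7 cells (Homo sapiens) for inhibition, read by MTT assay, with a stated time of 24 h; on this read-out higher numbers stand for weaker inhibition and lower numbers for stronger inhibition. Compound 1 gives 9100 nM, the lowest of the two numbers, with compound 3 nearest at 18200 nM, a gap that lies within the scatter. Compound 2 reaches only the limit (the limit of > 150000 nM in this assay, at which 1 of the 3 values shown sits), so it gives no number. For the measured compounds named here, the single step within the set, an at least 8.2-fold lower number from compound 2 to compound 3 (0.91 log units; beyond the scatter), changes one halogen for another on an aromatic carbon.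

Compound 4 `CCOC(=O)C1=Cc2ccccc2OC1(OCc1cn(CC(=O)Nc2ccc(OC)cc2)nn1)C(F)(F)F` is not yet measured. It differs from compound 1 by ((4-methoxyphenyl)carbamoyl)methyl in place of 4-fluorophenyl on an aromatic nitrogen. Going by the values given here, no measured step concerns this ring nitrogen or a group of this kind, so the halogen step gives no guide. With nothing to point either way, the expectation is no step beyond the scatter, a 1.3-fold higher number from compound 1 to compound 4 (0.12 log units; within the scatter), and compound 4 is estimated at 12000 nM, between 3000 nM and 60000 nM.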

Compound 4, half-maximal inhibitory concentration: 28100 nM
The estimate for compound 4 lay 2.3-fold (0.37 log units) below the measured number, and the stated range covers the measured number.
By their numbers in this assay, from the lowest: compounds 1, 3 and 4 (each within the scatter of the next, the first and the last beyond it). At a limit, above all of these: compound 2.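

For the compounds shown here, this is the first step at the aromatic nitrogen of the five-membered ring, and in this assay it reads as a 3.1-fold higher number from compound 1 to compound 4 (0.49 log units; beyond the scatter). The position therefore accepts a larger group, one that brings an amide hydrogen and a carbonyl, and the read-out remains a number rather than a limit, though inhibition is modestly weaker. Nothing measured in this set bears on why the number moved.

The change alters two things in one step, adding a carbamoylmethyl link and putting a 4-methoxyphenyl in place of the 4-fluorophenyl, so the compounds shown cannot say which part carries the step. They also leave open how this ring nitrogen would respond to a plain methyl, a longer carbon chain, or a chain ending in an amine or a carboxylic acid.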